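Chain shortening on the core of compound 1

The source may report more compounds than this note shows. Statements on the series, on what has been measured and on what is new or still open speak of the compounds shown alone.

Measured so far in a functional assay on HCT-116 cells (Homo sapiens) for inhibition, read by MTT assay, with a stated time of 72 h; a lower number here means a stronger inhibitor, a higher number a weaker inhibitor
- compound 1 `Nc1nc2cc(-c3nn(CCCCCCCCCC(=O)NO)c4ncnc(N)c34)ccc2o1` gives 23100 nM
- compound 2 `Nc1ncnc2c1c(-c1cnc3[nH]ccc3c1)nn2CCCCCCCCCC(=O)NO` gives 18700 nM

Compound 1 cannot be ranked against compound 2 because their values lie within the scatter of each other. Compound 3 `Nc1nc2cc(-c3nn(CCCCC(=O)NO)c4ncnc(N)c34)ccc2o1` shares the core of compound 1 and differs in the chain by hydroxycarbamoyl in place of 5-(hydroxycarbamoyl)pentyl on a saturated chain carbon, four bonds along the chain from an aromatic nitrogen with nothing else changed. Among the compounds with values here, the only measured step of a 1.2-fold lower number from compound 1 to compound 2 (0.09 log units; within the scatter) lies within the scatter and concerns the aromatic group on the core, not the chain. Within the data shown here, no measured step therefore bears directly on this change, and neither its size nor its direction is fixed by the data. A tentative move towards a lower number is expected, so the range stays wide. Expected in this assay is a 3.9-fold lower number from compound 1 to compound 3 (0.59 log units; beyond the scatter) as a rough estimate. For compound 3 the estimated value is 6000 nM with an expected range of 1000 nM to 30000 nM as a working figure.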

Compound 3, half-maximal inhibitory concentration: 34000 nM
The estimate for compound 3 lay 5.7-fold (0.75 log units) below the measured number; measured number outside the range, above it.
By their numbers in this assay, from the lowest: compounds 2, 1 and 3 (each within the scatter of the next).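

In this assay, the change from 5-(hydroxycarbamoyl)pentyl to hydroxycarbamoyl, on a saturated chain carbon four bonds along the chain from an aromatic nitrogen, gives a 1.5-fold higher number from compound 1 to compound 3 (0.17 log units; within the scatter) and so leaves the two compounds unranked. Within the data shown here, this is the first reading on the chain itself, as the earlier step concerned the aromatic group on the core, and it shows no separation between these two chain lengths on the core of compound 1. No supporting measurement is available to explain this reading.

Still open, going by these compounds, is whether a longer chain, or a chain of a length between those of compound 1 and compound 3, would give a step beyond the scatter on this core. Also open, on these data alone, is how a carboxylic acid in place of the terminal hydroxycarbamoyl would read at this position.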